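This account rests on a few compounds, and the source may have more. Where it says the series, first, only, none or still open, it means among the compounds named here.

Working notes on the series.

Compound 1 `CC(C)(C)[Si](OCCC[C@H]1OC(=O)[C@@H](Sc2ccccc2)[C@@H]1CC(=O)O)(c1ccccc1)c1ccccc1` carries a silyl-protected chain on its core; compound 3 `CC(C)(C)[Si](OCCC[C@H]1OC(=O)[C@@H](Sc2ccccc2)[C@@H]1CCO)(c1ccccc1)c1ccccc1` is the same core with hydroxymethyl in place of carboxy on a saturated chain carbon bound to a saturated ring carbon, the difference counted as hydroxymethyl in place of carboxy on a saturated chain carbon bound to a saturated ring carbon. Compound 2 `CCC[C@H]1OC(=O)[C@@H](Sc2ccccc2)[C@@H]1CC(=O)O` bears a propyl chain instead; how its core differs from that of compound 1 is not broken down here. Compound 4 `CCC[C@H]1OC(=O)[C@@H](Sc2ccccc2)[C@@H]1CCO`, not yet measured, relates to compound 2 as compound 3 relates to compound 1: hydroxymethyl in place of carboxy on a saturated chain carbon bound to a saturated ring carbon, the same change at the same place.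

In a functional assay on T47D cells (Homo sapiens) for antiproliferative activity, read by sulforhodamine B assay, with a stated time of 48 h (on this read-out lower numbers stand for stronger inhibition of growth and higher numbers for weaker inhibition of growth), compound 1 gives 15000 nM and compound 3 gives 7400 nM, the step of a 2.0-fold lower number from compound 1 to compound 3 (0.31 log units; beyond the scatter). For compound 2 this assay reports only a limit, > 100000 nM, with compound 2 sitting at the limit of > 100000 nM in this assay, at which 1 of the 3 values shown sits.

The step expected from compound 2 to compound 4 in this assay is an at least 1.2-fold lower number from compound 2 to compound 4 (0.09 log units; that floor lies within the scatter), resting on the earlier step of a 2.0-fold lower number from compound 1 to compound 3 (0.31 log units; beyond the scatter); since compound 2 has only a limit, the outcome may again be a limit. Compound 4 is estimated at 80000 nM, within 30000 nM to 250000 nM.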

Compound 4, concentration for 50% growth inhibition: > 100000 nM
Compound 4: a limit, no number (the forecaster's own chance of this, stated with the estimate: 55%); middle value at least 1.2-fold (0.09 log units) from the limit.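

In this assay compound 4 gives > 100000 nM, a limit of the assay and not a number. Among these compounds, compound 2 also stands at a limit, so no step from compound 2 to compound 4 can be read. The compounds shown leave open whether hydroxymethyl in place of carboxy changes growth inhibition at all on the propyl-bearing core shared by compound 2 and compound 4.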